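The source may hold more compounds than are shown below. What is called first, only, known or untested is meant among the compounds shown, and "the series" means these compounds.

Measured compounds, cytotoxicity:

Compound 1, `C=C1[C@@H](OC(C)=O)C[C@@H]2[C@](C)(COC=O)[C@H](OC(C)=O)CC[C@@]2(C)[C@@H]1C[C@@H](Nc1cccc(F)c1)C1=CCOC1=O`: in a functional assay on A549 cells (Homo sapiens) for cytotoxicity, read by sulforhodamine B assay (on this read-out lower numbers stand for stronger inhibition and higher numbers for weaker inhibition), compound 1 gives 23200 nM.
Compound 2, `C=C1[C@@H](OC(C)=O)C[C@@H]2[C@](C)(COC=O)[C@H](OC(C)=O)CC[C@@]2(C)[C@@H]1C/C=C1/C(=O)OC[C@H]1OC(C)=O`: in this assay compound 2 gives 19000 nM.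
Compound 3, `C=C1[C@@H](OC(C)=O)C[C@@H]2[C@](C)(CO[Si](C)(C)C(C)(C)C)[C@H](OC(C)=O)CC[C@@]2(C)[C@@H]1C[C@@H](Nc1cccc(F)c1)C1=CCOC1=O`: in this assay compound 3 gives 4060 nM.

Compound 1 and compound 2 share the diterpenoid-type portion but differ in the side chain; the difference between the two cores is not broken down here. Their values in this assay lie within the scatter of each other, so no order between them is claimed.

Compound 3 arises from compound 1 by a group of 7 heavy atoms (6 carbon, 1 silicon; no ring) in place of a group of 2 heavy atoms (1 carbon, 1 oxygen; no ring), on an oxygen on a saturated carbon, and this change gave a 5.7-fold lower number from compound 1 to compound 3 (0.76 log units; beyond the scatter).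

Compound 4, `C=C1[C@@H](OC(C)=O)C[C@@H]2[C@](C)(CO[Si](C)(C)C(C)(C)C)[C@H](OC(C)=O)CC[C@@]2(C)[C@@H]1C/C=C1/C(=O)OC[C@H]1OC(C)=O`, not yet measured, arises from compound 2 by the same change, (a group of 7 heavy atoms (6 carbon, 1 silicon; no ring) in place of a group of 2 heavy atoms (1 carbon, 1 oxygen; no ring), on an oxygen on a saturated carbon), at the same place. One instance of this change is known among the compounds shown, so the expectation rests on a single step.

Starting from compound 2 at 19000 nM, the step is expected to resemble the one from compound 1 to compound 3, that is a 5.6-fold lower number from compound 2 to compound 4 (0.75 log units; beyond the scatter), because a 5.7-fold lower number from compound 1 to compound 3 (0.76 log units; beyond the scatter) was found for the same change. Compound 4 is therefore estimated at 3400 nM in this assay, with a range expected from 1500 nM to 9000 nM.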

Compound 4, half-maximal inhibitory concentration: 4640 nM
The estimate for compound 4 lay 1.4-fold (0.14 log units) below the measured number; the range from low to high includes it.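

In this assay, replacing the formyl with the group of 7 heavy atoms (6 carbon, 1 silicon) on an oxygen on a saturated carbon gives a 4.1-fold lower number from compound 2 to compound 4 (0.61 log units; beyond the scatter). The change carries from one core to the other with no difference in size that can be told apart: the same change on two cores in this assay, a 5.7-fold lower number (0.76 log units; beyond the scatter) from compound 1 to compound 3 and a 4.1-fold lower number (0.61 log units; beyond the scatter) from compound 2 to compound 4, 1.4-fold (0.14 log units) apart, within the scatter of two such steps. This supports carrying the step between these two cores in this one cell read-out, but two instances do not establish it for the whole series, and they give no reason for the lower number.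

On these data alone, whether the lower number belongs to this particular entering group or simply to the loss of the formyl stays open, and a free hydroxyl, a benzyl ether or a trimethylsilyl group on the same oxygen would separate the two. Also open, as far as these compounds go, is whether the step holds on cores with other side chains, for example an aliphatic amine in place of the fluoroaniline of compound 1.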